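This account rests on a few compounds, and the source may have more. Where it says the series, first, only, none or still open, it means among the compounds named here.

Measured so far in an ADME assay on MT4 cells (Homo sapiens) for cytotoxicity, read by MTT assay, with a stated time of 4 days; a higher number here means that more compound is tolerated, a lower number that less compound is tolerated:
- compound 1 `COc1cccc(-c2cc(=O)c3cc(NC(C)=O)ccc3o2)c1`: > 404000 nM (a limit, not a number)
- compound 2 `CC(=O)Nc1ccc2oc(-c3cccc(C(F)(F)F)c3)cc(=O)c2c1`: 10000 nM

On these numbers, compound 1 stands at the limit of > 404000 nM in this assay, at which 1 of the 2 values shown sits.

Compound 3 `COc1cccc(-c2cc(=O)c3cc(N)ccc3o2)c1` keeps the core of compound 1 and changes in one place, on a nitrogen on an aromatic ring. There, hydrogen takes the place of acetyl, turning acetamido into amino: hydrogen in place of acetyl on a nitrogen on an aromatic ring.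

Among the compounds with values here, only one measured step is available: an at least 40-fold lower number from compound 1 to compound 2 (1.60 log units; beyond the scatter). That step swaps a different group, so it offers no direct measure of what losing acetyl does. It bears on this change only indirectly, showing that a single substitution on compound 1 can move the number in this assay a long way. A lower number is therefore expected for compound 3, though by less than in that step, and with wide uncertainty. It is also quite possible that compound 3 gives only a limit.

The expected step is an at least 2.6-fold lower number from compound 1 to compound 3 (0.43 log units; beyond the scatter).

The estimate for compound 3 is 150000 nM, with an expected range from 20000 nM to 470000 nM.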

Compound 3, half-maximal cytotoxic concentration: 247000 nM
For compound 3 the middle estimate is 1.6-fold (0.22 log units) below the measured one, within the range that was stated.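

Taking acetyl off the nitrogen on the aromatic ring gives the first look at this position in this assay, and the step reads an at least 1.6-fold lower number from compound 1 to compound 3 (0.21 log units; that floor lies within the scatter). On these data alone, that step is only a floor, and the floor lies within the usual scatter, so it does not by itself establish a real change, and the true size of the step stays unknown. Compound 1 gives only a limit, not a number: the limit of > 404000 nM in this assay, at which 1 of the 3 values shown sits.

Compound 3 gives 247000 nM, a real number rather than a limit, so the amino compound offers a fixed point for any later comparison at this nitrogen, which compound 1 cannot do.

The compounds shown leave open how other groups on this nitrogen would read, such as a longer acyl chain like propanoyl, a methyl group or a methanesulfonyl group. Also open, as far as these compounds go, is whether swapping acetamido for amino would act in the same way on compound 2, with trifluoromethyl in place of methoxy, where the starting point is a measured number rather than a limit.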